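Compound 2 gains a 2,4-dichlorophenyl group

This account rests on a few compounds, and the source may have more. Where it says the series, first, only, none or still open, it means among the compounds named here.

Measured so far:
Compound 1 `CCC(=O)c1cc(-c2ccc(Cl)cc2)n(-c2cccc(S(N)(=O)=O)c2)c1C` gives 200 nM
Compound 2 `CCC(=O)c1cc(-c2ccccc2)n(-c2ccc(S(N)(=O)=O)cc2)c1C` gives 14100 nM

In a physicochemical assay for solubility, read by HPLC, in phosphate buffer, measured as kinetic solubility, at pH 7.4 (on this read-out lower numbers stand for lower solubility and higher numbers for higher solubility), compound 2 gives 14100 nM as the highest of the two numbers, and compound 1 lies beyond the scatter below it. Compound 3 `CCC(=O)c1cc(-c2ccc(Cl)cc2Cl)n(-c2ccc(S(N)(=O)=O)cc2)c1C` carries 2,4-dichlorophenyl in place of phenyl on an aromatic carbon and has not been measured. Among the measured compounds shown here, no measured pair shows this change alone. For the measured compounds named here, the only guide is compound 1, which also carries chlorine and gives 200 nM in this assay despite other structural differences. The expected step is a drop beyond the scatter (a 9.4-fold lower number from compound 2 to compound 3 (0.97 log units; beyond the scatter)). Compound 3 is estimated at 1500 nM (expected range 300 nM to 7000 nM).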

Compound 3, solubility: 7700 nM
The estimate for compound 3 lay 5.1-fold (0.71 log units) below the measured number; measured number outside the range, above it.
By their numbers in this assay, from the lowest: compound 1; then compounds 3 and 2 (each within the scatter of the next).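

In this assay, 2,4-dichlorophenyl in place of phenyl, on the aromatic carbon next to the ring nitrogen, gives a 1.8-fold lower number from compound 2 to compound 3 (0.26 log units; within the scatter). At this position, then, the two chlorine atoms do not clearly separate the pair on this read-out, and the step alone cannot show that the change matters here. No supporting measurement explains this result. As far as these compounds go, what an amine or a carboxylic acid on this phenyl ring would do stays open. So does whether the same swap would give a similar step with the sulfonamide placed as in compound 1.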